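From Nitro to Methoxy on an Aromatic Carbon

The compounds below may be only part of what the source reports. "The series", "measured", "known", "first", "only" and "open" are said of these compounds alone.

In an ADME assay on HEL cells (Homo sapiens) for cytotoxicity (a lower number here means that less compound is tolerated, a higher number that more compound is tolerated), compound 2 (`O=C(COc1cccc2ccccc12)N/N=C/c1ccc([N+](=O)[O-])cc1`) gives 14.2 ug/mL on the half-maximal cytotoxic concentration read-out. Compound 3 (`C/C(=N\NC(=O)COc1cccc2ccccc12)c1ccc(Br)cc1`) gives 15.3 ug/mL and compound 1 (`COc1ccc(/C=N/NC(=O)COc2cccc3ccccc23)cc1O`) gives 27.7 ug/mL in the same test. Compound 2 thus stands within the usual scatter of both, and the numbers support no ranking around it.

Compound 4 (`COc1ccc(/C=N/NC(=O)COc2cccc3ccccc23)cc1`) has not yet been measured. It carries methoxy in place of nitro on an aromatic carbon, para to a large group (methoxy in place of nitro on an aromatic carbon). Within the data shown here, no two measured compounds differ in only one place, so the data hold no direct precedent for this change.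

The expectation rests on the values of compound 2 (14.2 ug/mL) and compound 1 (27.7 ug/mL), which remain within the scatter of each other. A small move toward a higher number is expected, not beyond the scatter. The expected change is a 1.4-fold higher number from compound 2 to compound 4 (0.15 log units; within the scatter) in this assay on this estimate. For compound 4 the estimated value is 20 ug/mL with an expected range (9 ug/mL to 45 ug/mL).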

Compound 4, half-maximal cytotoxic concentration: 100 ug/mL
Compound 4: middle estimate off by 5.0-fold (0.70 log units), on the low side; measured number above the stated range.
By their numbers in this assay, from the lowest: compounds 2, 3 and 1 (each within the scatter of the next); then compound 4.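

In this assay, among these compounds, this position, on an aromatic carbon para to a large group, turns out to matter: methoxy in place of nitro gives a 7.0-fold higher number from compound 2 to compound 4 (0.85 log units; beyond the scatter) and is the first change to lie beyond the scatter. Methoxy is not the whole story, since compound 1 also carries it and hydrogen in place of hydroxy on an aromatic carbon still gives a 3.6-fold higher number from compound 1 to compound 4 (0.56 log units; beyond the scatter) in the same test, so the neighbouring substituent counts as well. Nothing measured here explains either step.

The compounds shown leave open whether the higher number comes with methoxy itself or simply with the loss of nitro, as an amine or a chlorine atom at the same place would help to tell. They also leave open whether either step would hold on another core.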